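A few compounds are considered here, and "the series" means these few. Any claim that something is new, unique, unknown or untested is made for them only; others in the source may bear on it.

Compound 1 `O=C(NCc1cn(Cc2ccc(F)cc2)nn1)c1cn(-c2ccccc2)nc1-c1ccccc1` is the simplest of the four compounds here. In a functional assay on HeLa cells (Homo sapiens) for antiproliferative activity, read by sulforhodamine B assay, with a stated time of 48 h (a higher number here means a weaker inhibitor of growth, a lower number a stronger inhibitor of growth), compound 1 gives 1600 nM. Compound 2 `O=C(NCc1cn(Cc2ccc(Cl)cc2)nn1)c1cn(-c2ccccc2)nc1-c1ccccc1` differs from it in a single place: chloro in place of fluoro on an aromatic carbon. In this assay compound 2 gives 600 nM, which amounts to a 2.7-fold lower number from compound 1 to compound 2 (0.43 log units; beyond the scatter). Compound 3 `COc1ccc(-c2nn(-c3ccccc3)cc2C(=O)NCc2cn(Cc3ccc(F)cc3)nn2)cc1` keeps the fluoro of compound 1 but changes the shared core elsewhere: methoxy in place of hydrogen on an aromatic carbon. In this assay compound 3 gives 500 nM, a step of a 3.2-fold lower number from compound 1 to compound 3 (0.51 log units; beyond the scatter). The values of compound 2 and compound 3 lie within the usual scatter of each other, so nothing separates them.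

Compound 4 `COc1ccc(-c2nn(-c3ccccc3)cc2C(=O)NCc2cn(Cc3ccc(Cl)cc3)nn2)cc1` has not been measured. It stands to compound 3 exactly as compound 2 stands to compound 1: chloro in place of fluoro on an aromatic carbon. The surroundings of the place are described in the same words for both changes, so this is the same change, made a second time on the core of compound 3 instead of the core of compound 1. Within the data shown here, only one earlier instance exists, and the two cores differ, so it is not certain that the step repeats at full size. Still, a step of roughly a 2.0-fold lower number from compound 3 to compound 4 (0.30 log units; within the scatter) is expected from compound 3 to compound 4, because the first instance gave a 2.7-fold lower number from compound 1 to compound 2 (0.43 log units; beyond the scatter) and compound 3 starts from 500 nM. Compound 4 is therefore estimated at 250 nM, with a likely range from 120 nM to 600 nM.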

Compound 4, concentration for 50% growth inhibition: 6400 nM
Compound 4: the middle estimate sits 26-fold (1.41 log units) below what was measured, and the stated range ends below it.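

The chloro-for-fluoro change does not carry over between these two cores: with the methoxy group present, it gives a 13-fold higher number from compound 3 to compound 4 (1.11 log units; beyond the scatter) in this assay, whereas without that group it lowered the number, so the same edit moves growth inhibition in opposite directions: the same change on two cores in this assay, a 2.7-fold lower number (0.43 log units; beyond the scatter) from compound 1 to compound 2 and a 13-fold higher number (1.11 log units; beyond the scatter) from compound 3 to compound 4, 34-fold (1.53 log units) apart, beyond the scatter of two such steps

The methoxy change, read the other way round the same set of four compounds, tells the same story: with chloro rather than fluoro in place, it gives an 11-fold higher number from compound 2 to compound 4 (1.03 log units; beyond the scatter), although with fluoro it lowered the number: the same change on two cores in this assay, a 3.2-fold lower number (0.51 log units; beyond the scatter) from compound 1 to compound 3 and an 11-fold higher number (1.03 log units; beyond the scatter) from compound 2 to compound 4, 34-fold (1.53 log units) apart, beyond the scatter of two such steps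

This shows that, in these four compounds, the two changes do not simply add up and the result of each depends on the other, but it does not show why this happens or whether it holds for any other pair of changes, and a single set of four compounds cannot establish a rule for the series.

The compounds shown leave open whether this sharp loss is specific to the pairing of chloro and methoxy, or whether it also appears with bromo or methyl in place of the chloro. They also leave open what happens with ethoxy or hydroxy in place of the methoxy, and whether the same pattern appears outside this assay.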